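Cytotoxicity notes: tert-butyl in place of 2-chlorophenyl

The compounds below may be only part of what the source reports. "The series", "measured", "known", "first", "only" and "open" are said of these compounds alone.

Measured so far:
- compound 1 `CN1CCN(CCNCc2cn(-c3ccc(F)cc3F)nc2-c2ccc(N(C)C)cc2)CC1`; in an ADME assay on Huh-7 cells (Homo sapiens) for cytotoxicity (on this read-out higher numbers stand for lower toxicity in this test and lower numbers for higher toxicity in this test), compound 1 gives > 20000 nM, a limit.
- compound 2 `CN1CCN(CCNCc2cn(-c3ccc(F)cc3F)nc2-c2ccccc2Cl)CC1`; in this assay compound 2 gives > 20000 nM, a limit.

Compound 2 stands at the limit of this assay, as does compound 1 (the limit of > 20000 nM in this assay, at which 2 of the 2 values shown sit). Going by the values given here, the only measured step, a step that the two limits leave unreadable from compound 1 to compound 2, cannot be sized, so it gives no reading on how the group on this carbon moves this assay. Compound 3 `CN1CCN(CCNCc2cn(-c3ccc(F)cc3F)nc2C(C)(C)C)CC1` differs from compound 2 by tert-butyl in place of 2-chlorophenyl on an aromatic carbon. Among the compounds with values here, no measured step bears on this change. Compound 3 is therefore expected to remain at the limit, with an estimated 20000 nM (range 10000 nM to 40000 nM), meaning an expected step of a number no higher from compound 2 to compound 3 (the limit leaves the size open).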

Compound 3, half-maximal cytotoxic concentration: > 20000 nM
Compound 3 ended at the assay's limit (the forecaster's own chance of this, stated with the estimate: 70%); the middle value lies on the limit itself.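

No step among compound 1, compound 2 and compound 3 can be read in this assay, as all three values are limits: the limit of > 20000 nM in this assay, at which 3 of the 3 values shown sit.

The compounds shown leave open whether any group on this aromatic carbon brings a value in this assay off the limit.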